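The source may report more compounds than this note shows. Statements on the series, on what has been measured and on what is new or still open speak of the compounds shown alone.

Compound 1 `O=C(Nc1cccc(-n2cc(-c3ccncc3)c(-c3ccc(Cl)c(O)c3)n2)c1)Nc1cccc(C(F)(F)F)c1` and compound 2 `COc1cc(-c2nn(-c3cccc(NC(=O)Nc4ccc(Cl)c(C(F)(F)F)c4)c3)cc2-c2ccncc2)ccc1Cl` were both examined in a functional assay on OVCAR-5 cells (Homo sapiens) for inhibition, read by sulforhodamine B assay, with a stated time of 48 h; a lower number here means that less compound is tolerated, a higher number that more compound is tolerated. For compound 1 the assay returned only a limit, > 32500 nM. For compound 2 it likewise returned only a limit, > 32500 nM. Among the compounds with values here, compound 2 therefore stands on no scale of numbers: its reading is a limit of this assay, and the one other value shown is a limit of the same kind, both resting at the limit of > 32500 nM in this assay, at which 2 of the 2 values shown sit. Compound 3 `O=C(Nc1cccc(-n2cc(-c3ccncc3)c(-c3ccc(Cl)c(O)c3)n2)c1)Nc1ccc(Cl)c(C(F)(F)F)c1` has not yet been measured. It differs from compound 2 in one place, (hydrogen in place of methyl on an oxygen on an aromatic ring), that is, hydrogen in place of methyl on an oxygen on an aromatic ring, methoxy to hydroxy. Within the data shown here, no step between measured compounds is available to size this change. Compound 3 is expected to remain at the limit, so a step that the limit leaves unreadable from compound 2 to compound 3 is estimated as no step beyond the scatter of this assay. Compound 3 is accordingly estimated at 40000 nM, within the range 15000 nM to 100000 nM.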

Compound 3, concentration lethal to 50% of the cells: > 32500 nM
Compound 3 ended at the assay's limit (the forecaster's own chance of this, stated with the estimate: 80%); the middle value lies beyond the limit too.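

No step from compound 1 or compound 2 to compound 3 can be read, because all three compounds give the same limit: the limit of > 32500 nM in this assay, at which 3 of the 3 values shown sit.

As far as these compounds go, what the change from methoxy to hydroxy or the added chloro does in this assay stays open, as does where any of the three compounds truly lies.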